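Swapping a Cyclopropyl Urea for a Dimethyl Urea

A few compounds are considered here, and "the series" means these few. Any claim that something is new, unique, unknown or untested is made for them only; others in the source may bear on it.

Measured compounds:
Compound 1 `CNC(=O)NCc1ccccc1-c1ccc(CN2C(=O)[C@H](NC(=O)C(C)(C)N)CCc3ccccc32)cc1` — 1 nM
Compound 2 `CC(C)(N)C(=O)N[C@@H]1CCc2ccccc2N(Cc2ccc(-c3ccccc3CNC(=O)NC3CC3)cc2)C1=O` — 45 nM

Both measured compounds share one core and differ only at the far end of a urea. In a functional assay (Pituitary gland cell) with Rattus norvegicus as the target (a higher number here means that more compound is needed for the effect, a lower number that less compound is needed), compound 1 gives 1 nM. Within the data shown here, compound 2, which carries a cyclopropyl in place of the methyl on that amide-type nitrogen, gives 45 nM and so stands at the higher of the two numbers, with compound 1 the only neighbour: a 45-fold higher number from compound 1 to compound 2 (1.65 log units; beyond the scatter).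

Compound 3 `CN(C)C(=O)NCc1ccccc1-c1ccc(CN2C(=O)[C@H](NC(=O)C(C)(C)N)CCc3ccccc32)cc1` has not yet been measured. It differs from compound 2 as follows: dimethylamino in place of cyclopropylamino on a carbonyl carbon. Among the measured compounds shown here, the one step that bears on this is the change from compound 1 to compound 2, which was large. Compound 3 keeps two small carbon groups of roughly the size of the methyl in compound 1, but gives up the hydrogen-bond donor that both measured compounds carry, so the direction is uncertain. On balance a move back toward compound 1 is expected: a 4.5-fold lower number from compound 2 to compound 3 (0.65 log units; beyond the scatter). For compound 3 an estimate of 10 nM is expected in this assay, with a plausible range from 1.5 nM to 70 nM.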

Compound 3, concentration for half-maximal effect: 60 nM
Beside the measured number, compound 3's estimate is 6.0-fold (0.78 log units) below it, within the range that was stated.
By their numbers in this assay, from the lowest: compound 1; then compounds 2 and 3 (each within the scatter of the next).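

In this assay the change at this carbonyl carbon gives a 1.3-fold higher number from compound 2 to compound 3 (0.12 log units; within the scatter), so the dimethylamino and cyclopropylamino groups cannot be told apart here, even though the first has no hydrogen-bond donor and no ring while the second has both. Placing methyl in place of hydrogen on the amide-type nitrogen of compound 1 gives a 60-fold higher number from compound 1 to compound 3 (1.78 log units; beyond the scatter), a large step that shows a second carbon group at this end of the urea can carry almost the same cost as the cyclopropyl group. Compound 2 keeps its hydrogen on that nitrogen and still stands with compound 3, so among these compounds keeping that hydrogen does not by itself go with the low number of compound 1, and nothing measured here explains these numbers.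

Open, as far as these compounds go, is whether a plain amino group on the carbonyl carbon would stand near compound 1 or further from it. Open too, from the compounds shown here alone, is where an ethylamino group would fall, and so whether the number climbs gradually or sharply as the group grows beyond methylamino.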